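The source may report more compounds than this note shows. Statements on the series, on what has been measured and on what is new or still open speak of the compounds shown alone.

Measured compounds in a functional assay on HCT-116 cells (Homo sapiens) for inhibition, read by sulforhodamine B assay, with a stated time of 48 h; on this read-out higher numbers stand for weaker inhibition of growth and lower numbers for stronger inhibition of growth:
compound 1 `CN1CCN(CCCOc2cccc3nc(Nc4ccc(Cl)c(F)c4)ccc23)CC1` gives 1560 nM
compound 2 `CN1CCN(CCCOc2cccc3nc(Nc4ccc(F)c(F)c4)ccc23)CC1` gives 3800 nM

Within the data shown here, compound 2 stands at the higher of the two numbers; its only neighbour is compound 1, and the single measured step, a 2.4-fold higher number from compound 1 to compound 2 (0.39 log units; beyond the scatter), is all the series offers. Compound 3 `CN1CCN(CCCOc2cccc3nc(Nc4cc(Cl)cc(Cl)c4)ccc23)CC1` differs from compound 2 by 3,5-dichlorophenyl in place of 3,4-difluorophenyl on a nitrogen on an aromatic ring. Among the measured compounds shown here, the measured step bears on this only in part: fluoro in place of chloro raised the number modestly, so chloro in place of fluoro might be taken to lower it, but in compound 3 two chlorines enter and the ring changes from 3,4-difluorophenyl to 3,5-dichlorophenyl, and no measured pair covers that shift. A step down in this assay of roughly the size seen between compound 1 and compound 2 is therefore the working expectation, with wide uncertainty. Compound 3 is estimated at 1800 nM, within 600 nM to 5500 nM. The step this estimate implies is expected to be a 2.1-fold lower number from compound 2 to compound 3 (0.32 log units; beyond the scatter).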

Compound 3, concentration for 50% growth inhibition: 1940 nM
For compound 3 the middle estimate is 1.1-fold (0.03 log units) below the measured one, within the range that was stated.
By their numbers in this assay, from the lowest: compounds 1, 3 and 2 (each within the scatter of the next, the first and the last beyond it).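

Replacing 3,4-difluorophenyl by 3,5-dichlorophenyl on a nitrogen on an aromatic ring gives a 2.0-fold lower number from compound 2 to compound 3 (0.29 log units; within the scatter) in this assay, and replacing 4-chloro-3-fluorophenyl by the same group gives a 1.2-fold higher number from compound 1 to compound 3 (0.09 log units; within the scatter) in that read-out. Among these compounds, compound 3 therefore cannot be separated from either of the other two compounds, and this position accepts a change in both the halogens and their placement without a step beyond the scatter, although the single halogen exchange gave a 2.4-fold higher number from compound 1 to compound 2 (0.39 log units; beyond the scatter) as a modest step beyond it. No measurement at hand accounts for these numbers and, with halogen and placement changing together, their separate contributions cannot be read.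

Still open, going by these compounds, is how an unsubstituted phenyl, or a phenyl carrying methoxy or trifluoromethyl, would read at this nitrogen. A 3,5-difluorophenyl group would separate halogen identity from placement.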